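Dropping the methyl from the nitrophenyl compound

The compounds below may be only part of what the source reports. "The series", "measured", "known", "first", "only" and "open" are said of these compounds alone.

For the measured compounds named here, compound 1 `Cc1cnc(-c2cccc([N+](=O)[O-])c2)n2nc(N)nc12` gives 8700 nM in a functional assay (Homo sapiens) (a lower number here means a stronger inhibitor, a higher number a weaker inhibitor), the only number it has there; a further entry for it reports no value. Compound 2 `Nc1nc2ccnc(-c3cccc(Br)c3)n2n1`, which also lacks the methyl group, gives 3700 nM; 3700 nM (2 entries) in this assay. Compound 3 `Nc1nc2ccnc(-c3cccc([N+](=O)[O-])c3)n2n1` differs from compound 1 by hydrogen in place of methyl on an aromatic carbon. Going by the values given here, no measured pair shows this change on its own, so only a small step is expected in this assay, if anything toward a stronger inhibitor, and not clearly beyond the scatter. Compound 3 is expected at 6000 nM, between 2000 nM and 18000 nM, an estimated step of a 1.5-fold lower number from compound 1 to compound 3 (0.16 log units; within the scatter).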

Compound 3, half-maximal inhibitory concentration: 3800 nM
Estimate against measurement, compound 3: 1.6-fold (0.20 log units) above, within the range that was stated.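

In this assay, for the compounds shown here, hydrogen in place of methyl on this aromatic carbon gives a 2.3-fold lower number from compound 1 to compound 3 (0.36 log units; beyond the scatter), the first direct reading at this position; the methyl is not required for activity in this pair. Without the methyl, compound 3 gives 3800 nM and compound 2 gives 3700 nM; 3700 nM (2 entries), so the two values match. No measured evidence bears on the reason for the step.

On these data alone, whether the step carries over to the bromo-substituted compound 2 remains open. So does the outcome at this carbon with an ethyl group, an amine or a methoxy group.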